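Adding Chlorine to the Benzoyl Group of Compound 3

The compounds below may be only part of what the source reports. "The series", "measured", "known", "first", "only" and "open" are said of these compounds alone.

Three compounds with a shared core have so far been examined in a functional assay on NCI-H23 cells (Homo sapiens) for cytotoxicity, read by sulforhodamine B assay, with a stated time of 72 h; a higher number here means a weaker inhibitor of growth, a lower number a stronger inhibitor of growth. Compound 1 `CCCC(=O)N1c2ccccc2CCC1C(=O)Nc1ccccc1C(F)(F)F` carries a butanoyl group on the ring nitrogen. In this assay compound 1 gives only a limit, > 70000 nM. Compound 2 `CCC(=O)N1c2ccccc2CCC1C(=O)Nc1ccccc1C(F)(F)F` carries a propanoyl group instead. In this assay compound 2 likewise gives a limit, > 80000 nM. Among the measured compounds shown here, compound 3 `O=C(Nc1ccccc1C(F)(F)F)C1CCc2ccccc2N1C(=O)c1ccccc1`, with a benzoyl group at that position, is the only one with a real number: in this assay compound 3 gives 6340 nM, so it stands alone as the one measurable growth inhibitor of the three. The steps of an at least 11-fold lower number from compound 1 to compound 3 (1.04 log units; beyond the scatter) and an at least 12-fold lower number from compound 2 to compound 3 (1.10 log units; beyond the scatter) are both large and point toward stronger inhibition, whereas the step that the two limits leave unreadable from compound 1 to compound 2 cannot be read because both of its ends sit at the limits the limit of > 70000 nM in this assay, at which 1 of the 3 values shown sits, and (the limit of > 80000 nM in this assay, at which 1 of the 3 values shown sits).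

Compound 4 `O=C(Nc1ccccc1C(F)(F)F)C1CCc2ccccc2N1C(=O)c1ccc(Cl)cc1` differs from compound 3 by chloro in place of hydrogen on an aromatic carbon. For the measured compounds named here, no measured step concerns a substituent on the benzoyl ring; the two readable steps concerned the group attached directly to the carbonyl carbon. With nothing comparable to lean on, the step of a 1.3-fold lower number from compound 3 to compound 4 (0.10 log units; within the scatter) is expected to stay within the scatter, and compound 4 is estimated at 5000 nM in this assay, within a range of 1500 nM to 20000 nM.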

Compound 4, concentration for 50% growth inhibition: 307 nM
Compound 4: middle estimate off by 16-fold (1.21 log units), on the high side, outside the stated range (below it).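

Among the compounds shown here, compound 4 is the first case in which the benzoyl ring itself is changed, and it shows that this aromatic carbon is far from indifferent: in this assay, a single chlorine atom gives a 21-fold lower number from compound 3 to compound 4 (1.31 log units; beyond the scatter). The 4-chlorophenyl group therefore adds to what phenyl had already shown on the carbonyl carbon, with 4-chlorophenyl in place of ethyl giving an at least 260-fold lower number from compound 2 to compound 4 (2.41 log units; beyond the scatter) and 4-chlorophenyl in place of propyl giving an at least 220-fold lower number from compound 1 to compound 4 (2.35 log units; beyond the scatter), and both of these steps start from a limit of the assay rather than from a number. Nothing measured in this series accounts for the effect of the chlorine.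

Going by these compounds, with only chloro tested against hydrogen here, it remains open whether the change is particular to chlorine or would also appear with fluoro, bromo, methyl, methoxy or a carboxylic acid on the same carbon. On these data alone, it is equally open what chloro would do on the other carbons of that ring, and whether the step would hold if the trifluoromethyl group on the anilide ring gave way to another group.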